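The source may hold more compounds than are shown below. What is called first, only, known or untested is meant among the compounds shown, and "the series" means these compounds.

Working notes on the series. In a functional assay on FM3A cells (Mus musculus) for antiproliferative activity, with a stated time of 48 h (on this read-out lower numbers stand for stronger inhibition and higher numbers for weaker inhibition), compound 1 `Nc1ccc(/C=C/C(=O)c2ccccc2)cc1` gives 146000 nM and compound 2 `Nc1ccc(/C=C/C(=O)c2ccc(Cl)cc2)cc1` gives 178000 nM. Within the data shown here, compound 2 thus stands level with compound 1, the only other measured compound, within the scatter. Compound 3 `Nc1ccc(/C=C/C(=O)c2ccc(Br)cc2)cc1` is still unmeasured and differs from compound 2 by bromo in place of chloro on an aromatic carbon. Among the measured compounds shown here, the one measured step bearing on this change is chloro in place of hydrogen on an aromatic carbon, a 1.2-fold higher number from compound 1 to compound 2 (0.09 log units; within the scatter). That single step is a thin basis, but it gives no reason to expect a shift in either direction, so no step beyond the scatter is expected in this assay. The estimate corresponds to an expected 1.1-fold lower number from compound 2 to compound 3 (0.03 log units; within the scatter). For compound 3 the estimated value is 165000 nM, with an expected range of 85000 nM to 320000 nM.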

Compound 3, half-maximal inhibitory concentration: 120000 nM
Beside the measured number, compound 3's estimate is 1.4-fold (0.14 log units) above it, within the range that was stated.
By their numbers in this assay, from the lowest: compounds 3, 1 and 2 (each within the scatter of the next).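

In this assay, the position on an aromatic carbon para to a large group now carries hydrogen, chloro and bromo, and a second halogen there leaves the number within the scatter on both readings (bromo in place of chloro, a 1.5-fold lower number from compound 2 to compound 3 (0.17 log units; within the scatter); bromo in place of hydrogen, a 1.2-fold lower number from compound 1 to compound 3 (0.09 log units; within the scatter)). The earlier pair tested a single halogen against hydrogen, whereas compounds 1, 2 and 3 together show no separation among the three substituents at this position in this assay. No measurement at hand accounts for this result.

Still open, from the compounds shown here alone, is whether a group of another kind at this position, such as a methoxy group, a carboxylic acid or a longer chain, would give a step beyond the scatter. The compounds shown also leave open whether replacing the amino group on the other ring would change the number.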